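A hydroxyethyl chain on the amino group

The source may hold more compounds than are shown below. What is called first, only, known or untested is meant among the compounds shown, and "the series" means these compounds.

Measured so far:
Compound 1 `Cc1nn2c(O)cc(C3CCOCC3)nc2c1Cc1cccc(C(F)(F)F)c1C` gives 3.98 nM in an assay on isolated protein for inhibition of phosphatidylinositol 4,5-bisphosphate 3-kinase catalytic subunit beta isoform (Homo sapiens); a lower number here means a stronger inhibitor, a higher number a weaker inhibitor.
Compound 2 `Cc1nn2c(NO)cc(C3CCOCC3)nc2c1Cc1cccc(C(F)(F)F)c1C` gives 39.8 nM in this assay.

Among the compounds with values here, compound 2 stands at the higher of the two numbers, and the only measured step, a 10-fold higher number from compound 1 to compound 2 (1.00 log units; beyond the scatter), separates it from compound 1. That step swapped a hydroxy group on the shared core for a hydroxyamino group.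

Compound 3 `Cc1nn2c(NCCO)cc(C3CCOCC3)nc2c1Cc1cccc(C(F)(F)F)c1C` has not yet been measured. Its change from compound 2 is 2-hydroxyethyl in place of hydroxy on a nitrogen on an aromatic ring, that is, the hydroxyamino group becomes a (2-hydroxyethyl)amino group. Within the data shown here, no measured step alters the substituent on this nitrogen, so the single step in hand does not directly bear on it; it only shows that this part of the molecule is sensitive to change. With nothing pointing in either direction, the expectation for compound 3 is a number close to that of compound 2, a step of a 1.0-fold higher number from compound 2 to compound 3 (0.00 log units; within the scatter) that stays within the scatter, with a wide range on both sides. The estimate for compound 3 in this assay is 40 nM, between 10 nM and 160 nM.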

Compound 3, half-maximal inhibitory concentration: 1260 nM
Compound 3: middle estimate off by 32-fold (1.50 log units), on the low side; measured number outside the range, above it.
By their numbers in this assay, from the lowest: compound 1; then compound 2; then compound 3.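

In this assay the group carried on this nitrogen turns out to matter greatly, not just the presence of a nitrogen on the aromatic carbon: 2-hydroxyethyl in place of hydroxy gives a 32-fold higher number from compound 2 to compound 3 (1.50 log units; beyond the scatter) and moves the series further from its best number. Set against the plain hydroxy group, the (2-hydroxyethyl)amino group gives a 320-fold higher number from compound 1 to compound 3 (2.50 log units; beyond the scatter) on the same core, so both replacements seen at this position raise the number, and compound 1 stays the strongest inhibitor of the three. No measurement here explains why the number climbs so steeply with this chain, so the result stands as an observation only.

From the compounds shown here alone, whether a plain amine, a methylamino group or a longer chain such as 3-hydroxypropylamino would land nearer compound 1 or nearer compound 3 remains open. Going by these compounds, it is also open whether the hydroxy on the chain or the chain itself drives the change, a question that an ethylamino or a 2-methoxyethylamino group on the same nitrogen could help to separate.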